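Chain-extended pyridine acid awaits its receptor binding result

The compounds below may be only part of what the source reports. "The series", "measured", "known", "first", "only" and "open" are said of these compounds alone.

Compound 1: `O=C(O)CCCCCOc1cc(-c2ccccc2)cc(-c2ccc(F)cc2)n1` — 30 nM
Compound 2: `O=C(O)CCCCOc1cc(-c2ccccc2)cc(-c2ccccc2)n1` — 50 nM

Of the compounds shown here, two have been measured in an assay on cell membranes from spleen (Cavia porcellus) for binding affinity to leukotriene B4 receptor 1 (Homo sapiens); on this read-out higher numbers stand for weaker inhibition and lower numbers for stronger inhibition. Compound 1 has the structure `O=C(O)CCCCCOc1cc(-c2ccccc2)cc(-c2ccc(F)cc2)n1` and gives 30 nM. Compound 2, with the structure `O=C(O)CCCCOc1cc(-c2ccccc2)cc(-c2ccccc2)n1`, gives 50 nM; its number is the higher of the two, but the gap to compound 1 lies within the scatter, so the two results cannot be told apart. For the measured compounds named here, compound 1 and compound 2 differ in more than one place, so no single structural step between measured compounds is available as a guide.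

Compound 3, the structure `O=C(O)CCCCCCOc1cc(-c2ccccc2)cc(-c2ccccc2)n1`, has not yet been measured. It differs from compound 2 in one place: 2-carboxyethyl in place of carboxy on a saturated chain carbon, four bonds along the chain from an oxygen on an aromatic ring. The data offer nothing on what lengthening this chain does, so the step from compound 2 to compound 3 is expected to be small, with no confident direction beyond the scatter: a 1.3-fold lower number from compound 2 to compound 3 (0.10 log units; within the scatter). Compound 3 is accordingly estimated at 40 nM, with a range from 10 nM to 160 nM.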

Compound 3, half-maximal inhibitory concentration: 25 nM
The estimate for compound 3 lay 1.6-fold (0.20 log units) above the measured number; the measured number falls inside the stated range.
By their numbers in this assay, from the lowest: compounds 3, 1 and 2 (each within the scatter of the next).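

For the compounds shown here, compound 3 gives the first single-place comparison. In this assay, putting 2-carboxyethyl in place of carboxy on the saturated chain carbon, four bonds along the chain from an oxygen on an aromatic ring, gives a 2.0-fold lower number from compound 2 to compound 3 (0.30 log units; within the scatter), so this change leaves the two compounds indistinguishable on this read-out and shows that the acid-bearing chain can take this extension without a loss beyond the scatter. Nothing available explains this result or says how the chain is accommodated.

The compounds shown leave open how far this tolerance extends: a longer chain ending in a carboxylic acid, a much shorter one, or an amine or an ester at the chain end could each behave differently, and a single step cannot establish a trend with chain length. They also leave open what the fluorine of compound 1 contributes at a matched chain length, since compound 1 differs from both compound 2 and compound 3 in more than one place.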